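This account rests on a few compounds, and the source may have more. Where it says the series, first, only, none or still open, it means among the compounds named here.

Measured so far:
- compound 1, `N=C(NCCCc1c[nH]cn1)NCCC(c1ccccc1)c1ccccn1`, 7.39
- compound 2, `N=C(NCCCc1c[nH]cn1)NCCC(c1cccc(F)c1)c1ccccn1`, 7.88
- compound 3, `N=C(NCCCc1c[nH]cn1)NCCC(c1ccc(F)cc1)c1cccnc1`, 8.09

These three compounds were tested in a functional assay on cardiac atrium for agonist activity at histamine H2 receptor (Cavia porcellus); a higher number here means a more potent compound, by a factor of ten per unit of this negative logarithm, a lower number a less potent compound. Compound 3 holds the highest of the three numbers; its nearest neighbour is compound 2, which lies within the usual scatter of it, while compound 1 lies clearly lower. Going by the values given here, the only one-place step among the measured compounds is a number 0.49 log units higher from compound 1 to compound 2 (beyond the scatter), and it concerns a fluoro group, not the change considered here.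

Compound 4, `N=C(NCCCc1c[nH]cn1)NCCC(c1ccccc1)c1ccc(F)cc1`, differs from compound 3 by phenyl in place of pyridin-3-yl on a saturated chain carbon bound to an aromatic carbon and a saturated chain carbon. Among the compounds with values here, no measured pair shows the effect of exchanging the pyridine ring for a carbon-only ring, so there is no step that bears on it directly; the comparison of compound 1 with compound 3 mixes this change with others. With the hydrogen-bond acceptor of the ring removed, a moderate decrease in this assay seems the more likely outcome, and the step from compound 3 to compound 4 is expected at a number 0.79 log units lower from compound 3 to compound 4 (beyond the scatter). Compound 4 is therefore estimated at 7.3, with a plausible range from 6.6 to 8.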

Compound 4, negative logarithm of the half-maximal effective concentration: 7.73
Beside the measured number, compound 4's estimate is 0.43 log units below it, within the range that was stated.
By their numbers in this assay, from the lowest: compound 1; then compounds 4, 2 and 3 (each within the scatter of the next, the first and the last beyond it).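

In this assay, going by these compounds alone, phenyl in place of pyridin-3-yl gives a number 0.36 log units lower from compound 3 to compound 4 (beyond the scatter), the first direct reading of this ring exchange at this place, and it shows that the number responds to the exchange, though only modestly. At the same place, 4-fluorophenyl in place of pyridin-2-yl gives a number 0.34 log units higher from compound 1 to compound 4 (beyond the scatter), so going to a carbon-only ring lowers the number in one pair and raises it in the other, and a pyridine ring is not required for a number as high as that of compound 4. No measurement shown here explains why these two steps point in opposite directions.

Still open, on these data alone, is how a cyclohexyl or thienyl ring would fare at this place. Also open, as far as these compounds go, is whether a chloro group in place of the fluoro group of compound 4 would shift its number.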